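The source may hold more compounds than are shown below. What is called first, only, known or untested is meant among the compounds shown, and "the series" means these compounds.

In an ADME assay on TZM cells (Homo sapiens) for cytotoxicity, read by XTT assay, with a stated time of 4 days (a lower number here means that less compound is tolerated, a higher number that more compound is tolerated), compound 1 `Cc1cc(CCC#N)cc(C)c1Oc1cc(Nc2ccc(C#N)cc2)c(N)cc1C(=O)O` gives 14300 nM as a number. Compound 2 `CNC(=O)c1cc(N)c(Nc2ccc(C#N)cc2)cc1Oc1c(C)cc(CCC#N)cc1C` stands at > 9100 nM which is a limit. Compound 3 `Cc1cc(CCC#N)cc(C)c1Oc1cc(Nc2ccc(C#N)cc2)c(N)cc1CO` stands at > 23800 nM which is also a limit. Compound 4 `CNC(=O)c1cc(N)c(Nc2ccc(C#N)cc2)cc1Oc1c(C)cc(/C=C/C#N)cc1C` differs from compound 2 by 2-cyanoethenyl in place of 2-cyanoethyl on an aromatic carbon with 2-cyanoethenyl in place of 2-cyanoethyl on an aromatic carbon. Within the data shown here, no measured step changes this chain. The nearest evidence is a step that the limit leaves unreadable from compound 1 to compound 2 and a step that the two limits leave unreadable from compound 2 to compound 3 together with an at least 1.6-fold higher number from compound 1 to compound 3 (0.22 log units; that floor lies within the scatter) on the same side of the core. On these grounds no step beyond the scatter is expected in this assay for this change. The expected result is a step that the limit leaves unreadable from compound 2 to compound 4 by this estimate. For compound 4 the estimated value is 11000 nM within an expected range of 4000 nM to 30000 nM in this assay.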

Compound 4, half-maximal cytotoxic concentration: > 9200 nM
Compound 4 gave a limit, no number; the forecaster's own chance of this, stated with the estimate: 50%; the middle value does not contradict the limit.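

In this assay compound 2 gives only a limit, > 9100 nM. Compound 4 also gives only a limit, > 9200 nM, so no step can be read between these two compounds. The compounds shown leave open whether 2-cyanoethenyl in place of 2-cyanoethyl shifts the tolerated concentration at all.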